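A few compounds are considered here, and "the series" means these few. Any claim that something is new, unique, unknown or untested is made for them only; others in the source may bear on it.

Measured so far in this series:
- compound 1 `Cn1cncc1C(O)(c1ccc(C#N)cc1)c1cc2cc([N+](=O)[O-])cc(-c3ccccc3F)c2o1`: 89.5 nM
- compound 2 `Cn1cncc1[C@@](N)(c1ccc(C#N)cc1)c1cc2cc(C#N)cc(-c3cccc(C#N)c3)c2o1`: 2 nM

In a functional assay on QG-56 cells (Homo sapiens) for antiproliferative activity (on this read-out lower numbers stand for stronger inhibition and higher numbers for weaker inhibition), compound 1 stands at the highest of the two numbers; compound 2 gives a lower number, and the gap between compound 1 and compound 2 is beyond the scatter. For the measured compounds named here, no pair of measured compounds shows the change to be made next. Compound 3 `Cn1cncc1C(O)(c1ccc(C#N)cc1)c1cc2cc([N+](=O)[O-])cc(-c3ccccc3)c2o1` differs from compound 1 as follows: hydrogen in place of fluoro on an aromatic carbon. With nothing measured for such a change, the step is expected to be small, a 1.1-fold higher number from compound 1 to compound 3 (0.05 log units; within the scatter), and not beyond the scatter. Compound 3 is accordingly estimated at 100 nM, with a range from 40 nM to 250 nM.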

Compound 3, half-maximal inhibitory concentration: 1480 nM
Estimate against measurement, compound 3: 15-fold (1.17 log units) below; measured number outside the range, above it.
By their numbers in this assay, from the lowest: compound 2; then compound 1; then compound 3.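

In this assay, the 2-fluorophenyl to phenyl change is far from neutral: hydrogen in place of fluoro gives a 17-fold higher number from compound 1 to compound 3 (1.22 log units; beyond the scatter) and shows that the group on this aromatic carbon, ortho to a large group, matters for the read-out. The earlier compounds shown here offered no single-place reading of this position. No measurement at hand accounts for the size of this step.

Going by these compounds, whether a chloro or methoxy group on the same carbon would match fluoro remains open. Also open, on these data alone, is whether this step would hold on a different core.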